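A few compounds are considered here, and "the series" means these few. Any claim that something is new, unique, unknown or untested is made for them only; others in the source may bear on it.

Measured so far:
compound 1, `CCCCN(CC)c1cc(C)nc2c1NC(=O)CN2c1ccc(C)cc1C`: 3.9 nM
compound 2, `CCCCN(CC)c1cc(C)nc2c1NC(=O)CN2c1ccc(Br)cc1Cl`: 2.7 nM
compound 3, `CCCCN(CC)c1cc(C)nc2c1NC(=O)CN2c1ccc(Br)cc1Br`: 1.3 nM

In an assay on HEK-293T cells for displacement of a labelled ligand from corticotropin-releasing factor receptor 1 (Homo sapiens), read by scintillation counting, with a stated time of 2 h (on this read-out lower numbers stand for stronger inhibition and higher numbers for weaker inhibition), compound 3 gives the lowest of the three numbers; the steps of a 2.1-fold lower number from compound 2 to compound 3 (0.32 log units; beyond the scatter) and a 3.0-fold lower number from compound 1 to compound 3 (0.48 log units; beyond the scatter) both lie beyond the scatter, so compound 3 stands as the strongest binder shown. Compound 4, `CCCCN(CC)c1cc(C)nc2c1NC(=O)CN2c1ccc(C)cc1Br`, differs from compound 3 in one place: methyl in place of bromo on an aromatic carbon. Among the compounds with values here, the step of a 3.0-fold lower number from compound 1 to compound 3 (0.48 log units; beyond the scatter) bears most directly on this change: it swaps both methyl groups for bromo, while the change to compound 4 undoes only one such swap. The step of a 1.4-fold lower number from compound 1 to compound 2 (0.16 log units; within the scatter) is within the scatter. A modest rise in the number is therefore expected. For compound 4 the estimate is 2 nM, within 1 nM to 4.5 nM. This amounts to an expected step of a 1.5-fold higher number from compound 3 to compound 4 (0.19 log units; within the scatter).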

Compound 4, inhibition constant: 4.4 nM
Compound 4: the middle estimate sits 2.2-fold (0.34 log units) below what was measured; the measured number falls inside the stated range.
By their numbers in this assay, from the lowest: compound 3; then compounds 2, 1 and 4 (each within the scatter of the next).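

In this assay, the bromo para to a large group matters on its own: with the other bromo kept, methyl in its place gives a 3.4-fold higher number from compound 3 to compound 4 (0.53 log units; beyond the scatter). With methyl at this place, however, bromo for the other methyl gives only a 1.1-fold higher number from compound 1 to compound 4 (0.05 log units; within the scatter), and the change of aryl group gives a 1.6-fold higher number from compound 2 to compound 4 (0.21 log units; within the scatter), both within the scatter, so the gain from bromo appeared only in the dibromo compound. No measurement shown explains this. As far as these compounds go, it remains open whether iodo, methoxy or ethyl at this carbon would match bromo.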